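Guanidine for Amine on Two Related Cores

This account rests on a few compounds, and the source may have more. Where it says the series, first, only, none or still open, it means among the compounds named here.

Compound 1 `NCCCOc1ccccc1C(=O)Nc1nc2ccc(Oc3ccccc3)cc2s1` was tested in an assay on isolated protein for inhibition of Voltage-dependent N-type calcium channel subunit alpha-1B (Rattus norvegicus); on this read-out higher numbers stand for an effect only at larger amounts of compound and lower numbers for an effect already at smaller amounts. For compound 1 the read-out is a limit of the assay, > 100000 nM. Compound 2 `NC(N)=NCCCOc1ccccc1C(=O)Nc1nc2ccc(Oc3ccccc3)cc2s1` carries the change a group of 4 heavy atoms (1 carbon, 3 nitrogen; no ring) in place of one nitrogen atom, on a saturated chain carbon, three bonds along the chain from an oxygen on an aromatic ring and in this assay gives 33000 nM; the step of an at least 3.0-fold lower number from compound 1 to compound 2 (0.48 log units; beyond the scatter) is only a lower bound, since compound 1 sits at the limit of > 100000 nM in this assay, at which 1 of the 3 values shown sits. Compound 3 `NCCCOc1ccc(CNc2ccc(Oc3ccccc3)cc2)cc1` rests on another core; the difference between the two cores is not broken down here. In this assay compound 3 gives 34000 nM, a value within the scatter of compound 2. Compound 4 `NC(N)=NCCCOc1ccc(CNc2ccc(Oc3ccccc3)cc2)cc1` carries the same change on the core of compound 3, (a group of 4 heavy atoms (1 carbon, 3 nitrogen; no ring) in place of one nitrogen atom, on a saturated chain carbon, three bonds along the chain from an oxygen on an aromatic ring). Compound 4 is expected to give 12000 nM, between 4000 nM and 40000 nM. That estimate means a step of a 2.8-fold lower number from compound 3 to compound 4 (0.45 log units; beyond the scatter), and it rests on the measured step of an at least 3.0-fold lower number from compound 1 to compound 2 (0.48 log units; beyond the scatter), read as a lower bound only.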

Compound 4, half-maximal effective concentration: 21000 nM
Compound 4: middle estimate off by 1.8-fold (0.24 log units), on the low side, and the stated range covers the measured number.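

On the second core, the change gives a 1.6-fold lower number from compound 3 to compound 4 (0.21 log units; within the scatter) in this assay, so compound 3 and compound 4 cannot be told apart on this read-out. Set beside the step on the first core, the result reads: the same change on two cores in this assay, an at least 3.0-fold lower number (0.48 log units; beyond the scatter) from compound 1 to compound 2 and a 1.6-fold lower number (0.21 log units; within the scatter) from compound 3 to compound 4; the limit leaves it open whether they differ. Compound 1 gives > 100000 nM, a limit of the assay and not a number, and the data therefore show neither that the change carries over between the cores at the same size nor that it does not.

From the compounds shown here alone, whether a dimethylamine or a urea in the same place would read alike on both cores stays open. So does the outcome for a longer chain carrying the amine or the new group.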